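From thiophen-3-yl to thiophen-2-yl on a shared core

The source may hold more compounds than are shown below. What is called first, only, known or untested is meant among the compounds shown, and "the series" means these compounds.

Compound 1 `Cc1cn2c(/C=N/Nc3ccccn3)c(-c3ccc(Cl)c([N+](=O)[O-])c3)nc2s1` gives 16600 nM
Compound 2 `Cc1cc(-c2nc3sccn3c2/C=N/NC(=N)N)c(C)s1` gives 15500 nM
Compound 3 `N=C(N)N/N=C/c1c(-c2ccsc2)nc2n1CCS2` gives 19100 nM

These three readings come from a functional assay on cells (Leukemia cell, Homo sapiens) for inhibition (a lower number here means a stronger inhibitor of growth, a higher number a weaker inhibitor of growth), and lie close together. Compound 3, with its 19100 nM reading, sits within the scatter of both compound 1 and compound 2, so no ranking can be drawn among them.

Compound 4 `N=C(N)N/N=C/c1c(-c2cccs2)nc2n1CCS2` has the same atoms as compound 3, joined differently: thiophen-2-yl in place of thiophen-3-yl on an aromatic carbon is the whole change. Among the measured compounds shown here, no two measured compounds differ in just one place, so the data offer no direct precedent. Compound 2, at 15500 nM in this test, differs from compound 3 in more than one place yet stays within the scatter. A smaller change is therefore expected to produce no step beyond the scatter in this assay in either direction. The estimate for compound 4 is 17000 nM as a middle value, with an expected range of 8000 nM to 35000 nM around it. The estimated step of a 1.1-fold lower number from compound 3 to compound 4 (0.05 log units; within the scatter) is expected to be lost in the scatter.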

Compound 4, concentration for 50% growth inhibition: 18600 nM
Beside the measured number, compound 4's estimate is 1.1-fold (0.04 log units) below it, within the range that was stated.
By their numbers in this assay, from the lowest: compounds 2, 1, 4 and 3 (each within the scatter of the next).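

Among the compounds shown here, compounds 3 and 4 form the first pair here that differs in one place only. Thiophen-2-yl in place of thiophen-3-yl gives a 1.0-fold lower number from compound 3 to compound 4 (0.01 log units; within the scatter) in this assay and so shows that, on this aromatic carbon next to the ring nitrogen, the two ways of attaching the thiophene cannot be told apart in this test. The earlier compounds could not show this, since each differs from the others in more than one place, and nothing measured here offers an explanation for the result.

The compounds shown leave open whether a different kind of group on this carbon, such as an amine, a carboxylic acid or a longer carbon chain, would give a step beyond the scatter. They also leave open whether the same thiophene swap would read alike on the core of compound 2.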